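The compounds below may be only part of what the source reports. "The series", "measured", "known", "first", "only" and "open" are said of these compounds alone.

In a functional assay on HT-1080 cells (Homo sapiens) for cytotoxicity, read by MTT assay, with a stated time of 72 h (a lower number here means a stronger inhibitor, a higher number a weaker inhibitor), three compounds have been measured so far:
Compound 1 `COc1cccc(/C=C2\CCC/C(=C\c3cccc(O)c3)C2=O)c1OC` gives 8500 nM.
Compound 2 `COc1cccc(/C=C2\CCC/C(=C\c3ccc(O)cc3)C2=O)c1OC` gives > 20000 nM, which is a limit of the assay rather than a number.
Compound 3 `COc1ccc(/C=C2\CCC/C(=C\c3cccc(O)c3)C2=O)cc1OC` gives 1700 nM.

Compound 1 and compound 3 carry the same atoms on different cores; the difference between the two cores is not broken down here. On the core of compound 1, the change 4-hydroxyphenyl in place of 3-hydroxyphenyl on a double-bonded chain carbon bound to a double-bonded ring carbon produced an at least 2.3-fold higher number from compound 1 to compound 2 (0.37 log units; beyond the scatter). Compound 2 sits at the limit of > 20000 nM in this assay, at which 1 of the 3 values shown sits. Compound 4 `COc1ccc(/C=C2\CCC/C(=C\c3ccc(O)cc3)C2=O)cc1OC` carries the same change on the core of compound 3: 4-hydroxyphenyl in place of 3-hydroxyphenyl on a double-bonded chain carbon bound to a double-bonded ring carbon. Since compound 3 starts from the lower number of 1700 nM, a weakening of similar size is expected, so the step from compound 3 to compound 4 is estimated as a 2.9-fold higher number from compound 3 to compound 4 (0.47 log units; beyond the scatter) in this assay. Compound 4 is therefore expected to give about 5000 nM, most likely between 2500 nM and 15000 nM.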

Compound 4, half-maximal inhibitory concentration: 16800 nM
Estimate against measurement, compound 4: 3.4-fold (0.53 log units) below; measured number above the stated range.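

In this assay, putting 4-hydroxyphenyl in place of 3-hydroxyphenyl gives a 9.9-fold higher number from compound 3 to compound 4 (0.99 log units; beyond the scatter). The number rises on both cores, so the direction of the change carries over, although compound 2 gives only a limit of the assay, > 20000 nM, and not a number. This does not show that the size of the change carries over as well: the same change on two cores in this assay, an at least 2.3-fold higher number (0.37 log units; beyond the scatter) from compound 1 to compound 2 and a 9.9-fold higher number (0.99 log units; beyond the scatter) from compound 3 to compound 4; the limit leaves it open whether they differ

The compounds shown leave open whether an amine or a carboxylic acid in place of the hydroxyl group would fit the same pattern. They also leave open how this change behaves on any core other than these two.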